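Widening the amine ring: cyclopropyl to cyclopentyl

This account rests on a few compounds, and the source may have more. Where it says the series, first, only, none or still open, it means among the compounds named here.

Compound 3 `CCOC(=O)c1cnc(NC2CC2)n2nc(-c3ccco3)nc12` carries an ethyl ester and a cyclopropylamino group, and in a functional assay on CHO cells for antagonist activity at adenosine receptor A2b (Homo sapiens) (a lower number here means a stronger inhibitor, a higher number a weaker inhibitor), compound 3 gives 2260 nM. For the measured compounds named here, that is the only number among the three values shown; the other two are limits. Compound 1 `CNC(=O)c1cnc(NC(=O)NC2CCCCC2)n2nc(-c3ccco3)nc12` is a urea bearing a methylamide, and in this assay compound 1 gives > 30000 nM, which is a limit of the assay and not a number. Compound 2 `O=C(Nc1ncc(C(=O)O)c2nc(-c3ccco3)nn12)NC1CCCCC1` differs from compound 1 by hydroxy in place of methylamino on a carbonyl carbon, and in this assay compound 2 gives > 30000 nM, again a limit. The step that the two limits leave unreadable from compound 1 to compound 2 cannot be read because both ends sit at the limit of > 30000 nM in this assay, at which 2 of the 3 values shown sit. Compound 4 `CCOC(=O)c1cnc(NC2CCCC2)n2nc(-c3ccco3)nc12` arises from compound 3 by cyclopentyl in place of cyclopropyl on a nitrogen on an aromatic ring. Going by the values given here, no measured step touches this change: compounds 1 and 2 differ from compound 3 in several places and give only limits. The expectation therefore rests on compound 3 alone, and the step of a 1.5-fold lower number from compound 3 to compound 4 (0.18 log units; within the scatter) is expected to stay within the scatter. Compound 4 is thus estimated at 1500 nM, in a range from 400 nM to 6000 nM.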

Compound 4, inhibition constant: 4620 nM
Estimate against measurement, compound 4: 3.1-fold (0.49 log units) below; the range from low to high includes it.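

In this assay, the change from cyclopropyl to cyclopentyl on a nitrogen on an aromatic ring gives a 2.0-fold higher number from compound 3 to compound 4 (0.31 log units; beyond the scatter), a modest step towards weaker inhibition that lies beyond the scatter. For the compounds shown here, this is the first step that can be read, and it shows that the number responds to the ring on this nitrogen while the ethyl ester and the rest of the core stay the same. Compounds 1 and 2 could not show this: they differ from compound 3 in several places, and the step between them cannot be read.

Going by these compounds, whether cyclobutyl, cyclohexyl or an open chain such as isopropyl on this nitrogen would continue the rise in the number remains open. Nothing measured here accounts for the size of this step.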